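Adding a Nitro Group to Compound 2

The compounds below may be only part of what the source reports. "The series", "measured", "known", "first", "only" and "open" are said of these compounds alone.

Compound 1 (`O=C(CCCCC1CCSS1)NO`) and compound 2 (`O=C(CCCCC1CCSS1)Nc1cccc(C(F)(F)F)c1`) have the shared core in common. Among the compounds with values here, in a functional assay on PC-3 cells (Homo sapiens) for inhibition, read by MTT assay, with a stated time of 24 h, tested at 10 ug/mL (on this read-out higher numbers stand for more inhibition of growth at the one concentration tested and lower numbers for less inhibition of growth), compound 1 stands at "not determined" (no result reported) with no result to compare, whereas compound 2 reaches 38.5% as the only number available, so it cannot yet be ranked against any other compound. Compound 3 (`O=C(CCCCC1CCSS1)Nc1ccc([N+](=O)[O-])c(C(F)(F)F)c1`) remains unmeasured. It departs from compound 2 in one place (nitro in place of hydrogen on an aromatic carbon) with nitro in place of hydrogen on an aromatic carbon, ortho to a trifluoromethyl group and para to a large group. Within the data shown here, no measured step between closely related compounds is available to guide the size of this change. A small upward move in this assay is expected, and it may well stay within the usual scatter. The estimated step is a number 3.5 percentage points higher from compound 2 to compound 3 (within the scatter) and remains tentative. Among the measured compounds shown here, that expectation starts from compound 2 at 38.5% and rests on the single structural change alone. For compound 3 the expected value is 42% with an estimated range of 24% to 60% across repeated measurements.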

Compound 3, percent growth inhibition at one concentration: "not active" (no number reported)
Nothing numeric was reported for compound 3; there is nothing to compare the estimate with.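

Within the data shown here, no step from compound 2 to compound 3 can be read in this assay as compound 3 carries the entry "not active" (no number reported) without a number. The compounds shown leave open how far nitro in place of hydrogen on an aromatic carbon shifts growth inhibition. Nothing shown bears on the reason for this result.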